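Thioester sulfonamides: replacing the piperidinyl ether with a methoxypropyl ether

The source may report more compounds than this note shows. Statements on the series, on what has been measured and on what is new or still open speak of the compounds shown alone.

Compound 1, `CC(=O)SCC(=O)c1ccc(NS(=O)(=O)c2ccc(OCCCN3CCCCC3)cc2)nc1`, gives 1000 nM in a functional assay on HCT-116 cells (Homo sapiens) for cytotoxicity; a higher number here means that more compound is needed for the effect, a lower number that less compound is needed. Compound 2, `CC(=O)SCC(=O)c1ccc(NS(=O)(=O)c2ccc(OCc3ccccn3)cc2)nc1`, gives 420 nM. Compound 3, `CC(=O)SCC(=O)c1ccc(NS(=O)(=O)c2ccc(OC3CCN(C)CC3)cc2)nc1`, gives 180 nM.

Compound 3 stands lowest of the three in this assay; the step of a 2.3-fold lower number from compound 2 to compound 3 (0.37 log units; beyond the scatter) and the step of a 5.6-fold lower number from compound 1 to compound 3 (0.74 log units; beyond the scatter) both lie beyond the scatter, so compound 3 needs the least compound for the effect among the measured set. Compound 4, `COCCCOc1ccc(S(=O)(=O)Nc2ccc(C(=O)CSC(C)=O)cn2)cc1`, has not been measured. It differs from compound 3 in one place: 3-methoxypropyl in place of 1-methylpiperidin-4-yl on an oxygen on an aromatic ring.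

The two steps that end at compound 3 both swap one group on that aromatic oxygen for the 1-methylpiperidin-4-yl group and both lower the number by a modest amount. Within the data shown here, compound 4 moves away from that group to a chain without a ring or nitrogen, a change no measured pair covers directly. Compound 4 is therefore expected to give a higher number than compound 3, with the step estimated at a 3.3-fold higher number from compound 3 to compound 4 (0.52 log units; beyond the scatter). Compound 4 is estimated at 600 nM, within 250 nM to 1500 nM.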

Compound 4, half-maximal effective concentration: 5300 nM
Compound 4: the middle estimate sits 8.8-fold (0.95 log units) below what was measured; the measured number lies above the stated range.
By their numbers in this assay, from the lowest: compound 3; then compound 2; then compound 1; then compound 4.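

In this assay, among these compounds, the 3-methoxypropyl group on the oxygen on the aromatic ring sets compound 4 above all three earlier compounds, with a 29-fold higher number from compound 3 to compound 4 (1.47 log units; beyond the scatter) and a 13-fold higher number from compound 2 to compound 4 (1.10 log units; beyond the scatter) both large, whereas the earlier steps at this position were all modest. Compound 4 is also the only one of the four whose group holds no ring and no nitrogen, and a 5.3-fold higher number from compound 1 to compound 4 (0.72 log units; beyond the scatter) shows that, on the same chain, methoxy at the end gives a higher number than piperidin-1-yl. Nothing among the data shown accounts for the size of these steps.

The compounds shown leave open whether the nitrogen or the ring matters more at this position. A 3-(dimethylamino)propyl group would keep the nitrogen without a ring, and a tetrahydropyran-4-yl group would keep a ring without nitrogen.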